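Removing a Fluorine: Two Places, Two Expectations

This account rests on a few compounds, and the source may have more. Where it says the series, first, only, none or still open, it means among the compounds named here.

Of the compounds shown here, three have been measured in a functional assay on HCT-116 cells (Homo sapiens) for antiproliferative activity, read by MTT assay, with a stated time of 48 h; on this read-out higher numbers stand for weaker inhibition and lower numbers for stronger inhibition. Compound 1 `Cc1cnc(Nc2ccc(S(C)(=O)=O)cc2)nc1Nc1nc2ccccc2s1` gives 760 nM. Compound 2 `Cc1cnc(Nc2ccc(S(C)(=O)=O)cc2)nc1Nc1nc2ccc(F)cc2s1` gives 24000 nM. Compound 3 `COc1ccc2nc(Nc3nc(Nc4ccc(S(N)(=O)=O)cc4)ncc3F)sc2c1` gives 11500 nM; compared with compound 2 the difference between the two cores is not broken down here.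

The step from compound 2 to compound 1 is hydrogen in place of fluoro on an aromatic carbon, sitting on an aromatic carbon of a six-membered aromatic ring of carbon only, part of a fused or bridged system of two rings; meta to a fused ring; para to a fused ring. It made a 32-fold lower number from compound 2 to compound 1 (1.50 log units; beyond the scatter) in this assay.

Compound 4 `COc1ccc2nc(Nc3ccnc(Nc4ccc(S(N)(=O)=O)cc4)n3)sc2c1`, not yet measured, is reached from compound 3 by hydrogen in place of fluoro on an aromatic carbon. This is the same kind of change, but not the same: here the place is on an aromatic carbon of a six-membered aromatic ring with 2 nitrogen; ortho to a large group; two atoms from the ring nitrogen; para to a large group, rather than on the carbon-only ring of the fused system.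

Because the earlier step of a 32-fold lower number from compound 2 to compound 1 (1.50 log units; beyond the scatter) was made at a different place, it is only a loose guide. For compound 4 the step from compound 3 is expected to be a 2.9-fold lower number from compound 3 to compound 4 (0.46 log units; beyond the scatter), smaller and less certain than the earlier one. In this assay compound 4 is thus expected to give about 4000 nM, most likely between 800 nM and 20000 nM.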

Compound 4, half-maximal inhibitory concentration: 1480 nM
Beside the measured number, compound 4's estimate is 2.7-fold (0.43 log units) above it; low and high end bracket the measured number.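

In this assay, taking the fluoro group off the ring with 2 nitrogen and putting hydrogen there gave a 7.8-fold lower number from compound 3 to compound 4 (0.89 log units; beyond the scatter), so on this core too the loss of fluorine goes with stronger inhibition. The direction of the change carried over from one core to the other, but its size did not, and the two steps differ by more than repeat measurements would explain: the same change on two cores in this assay, a 32-fold lower number (1.50 log units; beyond the scatter) from compound 2 to compound 1 and a 7.8-fold lower number (0.89 log units; beyond the scatter) from compound 3 to compound 4, 4.1-fold (0.61 log units) apart, beyond the scatter of two such steps This does not show why the sizes differ, since the fluorine sits at a different place in each pair and the two cores are not the same, so these two pairs cannot separate the effect of the place from that of the surrounding structure; two pairs also cannot establish a rule for any further core in this series, and a newcomer's safest reading is that the sign was repeated here while the size must be measured each time.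

Each of the two places is shown only with fluoro or hydrogen, so it stays open how a chlorine atom or a nitrile on the same carbon would compare. As far as these compounds go, it also stays open whether the same fluorine removal would give a similar result on other cell lines.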